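Swapping a Side Chain: From Neopentyl to 3-Methoxypropyl

This account rests on a few compounds, and the source may have more. Where it says the series, first, only, none or still open, it means among the compounds named here.

In a functional assay (strain AB) with Danio rerio as the target, read by microscopy, with a stated time of 1 h (a higher number here means that more compound is needed for the effect, a lower number that less compound is needed), compound 1 (`NC(=O)c1c(NC(=O)Nc2ccc(Cl)cc2)sc2c1CCN(CC1CCCCC1)C2`) gives 1890 nM. Compound 2 (`CCN1CCc2sc(NC(=O)Nc3ccc(Cl)cc3)c(C(N)=O)c2CC1`) gives 5800 nM, and compound 3 (`CC(C)(C)CN1CCc2c(sc(NC(=O)Nc3ccc(Cl)cc3)c2C(N)=O)C1`) gives 5560 nM. The values of compound 2 and compound 3 lie within the usual scatter of each other, so the two stand level, and both need more compound than compound 1.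

Compound 4 (`COCCCN1CCc2c(sc(NC(=O)Nc3ccc(Cl)cc3)c2C(N)=O)C1`) alters compound 3 in one place: 2-methoxyethyl in place of tert-butyl on a saturated chain carbon bound to an amine nitrogen in a ring. There, 2-methoxyethyl takes the place of tert-butyl on a saturated chain carbon bound to an amine nitrogen in a ring.

Within the data shown here, one measured step bears on this change: a 2.9-fold higher number from compound 1 to compound 3 (0.47 log units; beyond the scatter). Among the measured compounds shown here, it is a modest step at the same place, but it involves a different pair of groups, and no measured compound carries 2-methoxyethyl. A smaller change is therefore expected here, probably within the scatter. The estimated step is a 1.4-fold lower number from compound 3 to compound 4 (0.14 log units; within the scatter) in this assay. The estimate for compound 4 is 4000 nM, with an expected range of 1600 nM to 10000 nM.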

Compound 4, half-maximal effective concentration: 2400 nM
The estimate for compound 4 lay 1.7-fold (0.22 log units) above the measured number; low and high end bracket the measured number.
By their numbers in this assay, from the lowest: compounds 1 and 4 (each within the scatter of the next); then compounds 3 and 2 (each within the scatter of the next).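

In this assay, the exchange of neopentyl for 3-methoxypropyl gives a 2.3-fold lower number from compound 3 to compound 4 (0.36 log units; beyond the scatter), so this position responds to a change that leaves the count of heavy atoms the same but brings in an oxygen and a hydrogen-bond acceptor. Set against the cyclohexyl group, 3-methoxypropyl gives a 1.3-fold higher number from compound 1 to compound 4 (0.10 log units; within the scatter), so compound 4 stands level with compound 1 and, among these compounds, a cyclohexyl ring is not required at this place to reach that level. No measurement shown here explains the shift.

Still open, as far as these compounds go, is whether the oxygen matters or the unbranched chain alone does, and a plain pentyl chain at this place would separate the two. Also open, from the compounds shown here alone, is how a chain ending in an amine or a carboxylic acid would read here.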